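Solubility notes on a methylcarbamoyl pyridone series

The source may report more compounds than this note shows. Statements on the series, on what has been measured and on what is new or still open speak of the compounds shown alone.

Measured so far:
- compound 1, `CNC(=O)c1cc(C(=O)NC2CCC2)cn(Cc2ccncc2)c1=O`: >= 118 ug/mL
- compound 2, `CNC(=O)c1cc(C(=O)NC2CC2)cn(CC2CCCOC2)c1=O`: >= 131 ug/mL
- compound 3, `CNC(=O)c1cccn(Cc2ccccc2)c1=O`: 78 ug/mL

Among the measured compounds shown here, in a physicochemical assay for solubility (on this read-out higher numbers stand for higher solubility and lower numbers for lower solubility), compound 3 gives 78 ug/mL, the only plain number in the set. Compound 1 sits at a limit of the assay, >= 118 ug/mL. Compound 2 likewise sits at a limit, >= 131 ug/mL. Both limits, the limit of >= 118 ug/mL in this assay, at which 1 of the 3 values shown sits, and (the limit of >= 131 ug/mL in this assay, at which 1 of the 3 values shown sits), lie higher than the number for compound 3.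

Compound 4, `CCNC(=O)c1cc(C(=O)NC)c(=O)n(Cc2ccccc2)c1`, differs from compound 3 by ethylcarbamoyl in place of hydrogen on an aromatic carbon. For the measured compounds named here, no measured pair in the set follows this same change, so the step is guessed from the two limit compounds, which carry a second carbamoyl group and reach the limits. The step from compound 3 to compound 4 is expected to be a 1.7-fold higher number from compound 3 to compound 4 (0.22 log units; within the scatter), upward and beyond the scatter. Compound 4 is estimated at 130 ug/mL, between 60 ug/mL and 280 ug/mL.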

Compound 4, solubility: >= 144 ug/mL
Compound 4 gave a limit, no number (the forecaster's own chance of this, stated with the estimate: 40%); at least 1.1-fold (0.04 log units) between middle value and limit.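

Compound 4 reads at a limit in this assay, not at a plain number: the limit of >= 144 ug/mL in this assay, at which 1 of the 4 values shown sits.
Ethylcarbamoyl in place of hydrogen on the aromatic carbon two atoms from the ring nitrogen gives the first one-place step in the series (an at least 1.8-fold higher number from compound 3 to compound 4 (0.26 log units; that floor lies within the scatter)).
The step has only a floor, and that floor does not clear the scatter, so its true size at this position stays unread.

Open, going by these compounds, is whether an amine or a carboxylic acid at this position would give a plain number. Also open, on these data alone, is whether a longer chain on the carbamoyl would.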